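Oxolane in place of oxane: an expected half-life

This account rests on a few compounds, and the source may have more. Where it says the series, first, only, none or still open, it means among the compounds named here.

Compound 1 `N=c1c2c(-c3ccccc3)c(-c3ccccc3)n(CC3CC3)c2ncn1CC1CCOCC1` gives 0.272 h in an ADME assay on microsomes from liver (Mus musculus, strain CD1) for metabolic stability, read by LC-MS, using NADPH, with a stated time of 60 min; a lower number here means that the compound disappears faster, a higher number that the compound lasts longer.
Compound 2 `COc1ccc(Cn2c(-c3ccccc3)c(-c3ccccc3)c3c(=N)n(CC4CCOCC4)cnc32)cc1` gives 0.217 h in this assay.
Compound 3 `N=c1c2c(-c3ccccc3)cn(Cc3ccccc3)c2ncn1CCO` gives 0.153 h in this assay.

In this assay compound 2 holds the second highest of the three numbers. Its nearest neighbour is compound 1, whose number is higher by a margin within the scatter, and the furthest is compound 3, whose number is lower by a margin that is also within the scatter. For the measured compounds named here, the only step between measured compounds that differ in one place, a 1.3-fold lower number from compound 1 to compound 2 (0.10 log units; within the scatter), sits at the benzylic position on the shared core and lies within the scatter.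

Compound 4 `COc1ccc(Cn2c(-c3ccccc3)c(-c3ccccc3)c3c(=N)n(CC4CCCO4)cnc32)cc1` differs from compound 2 in one place: oxolan-2-yl in place of oxan-4-yl on a saturated chain carbon bound to an aromatic nitrogen. Going by the values given here, none of the three measured compounds isolates this change, so no measured step bears on it directly. Among the compounds with values here, the single step that is known, a 1.3-fold lower number from compound 1 to compound 2 (0.10 log units; within the scatter), concerns another position and gives no lead in either direction. Compound 4 is therefore expected to show a step that stays within the scatter, a 1.0-fold higher number from compound 2 to compound 4 (0.01 log units; within the scatter). In this assay compound 4 is estimated at 0.22 h, with a range from 0.11 h to 0.45 h.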

Compound 4, half-life: 0.157 h
Estimate against measurement, compound 4: 1.4-fold (0.15 log units) above; the range from low to high includes it.
By their numbers in this assay, from the lowest: compounds 3, 4, 2 and 1 (each within the scatter of the next).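

In this assay, the ring on a saturated chain carbon bound to an aromatic nitrogen now has a measured step of its own, a 1.4-fold lower number from compound 2 to compound 4 (0.14 log units; within the scatter), and it stays within the scatter, so the exchange of oxan-4-yl for oxolan-2-yl gives no clear shift in half-life on this background. For the compounds shown here, the earlier step concerned the other substituted place on the shared core, so this is the only reading for this place. The exchange alters ring size and the point of attachment in one step, with the hydrogen-bond donor and acceptor counts and the absence of net charge staying the same, and the step cannot assign any part of the small difference to either alteration; nothing available here gives a reason for the result.

The compounds shown leave open whether oxolan-3-yl, which keeps the five-membered ring but moves the point of attachment, would also stay within the scatter of compound 2. They also leave open how an amine such as piperidin-4-yl or an open chain such as 2-methoxyethyl would read at this place.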